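Swapping the Amide Alkyl Group for a Benzimidazole

The compounds below may be only part of what the source reports. "The series", "measured", "known", "first", "only" and "open" are said of these compounds alone.

Of the compounds shown here, three that share one core have been tested in an ADME assay on Vero cells (Chlorocebus sabaeus) for cytotoxicity; a higher number here means that more compound is tolerated, a lower number that less compound is tolerated. Compound 1 `O=C(Nc1ccccc1)c1cccc2[nH]c(-c3cccnc3)nc12` gives 34.2 uM. Compound 2 `CCC(CC)NC(=O)c1cccc2[nH]c(-c3ccc(OC)c(OC)c3)nc12` gives 2.23 uM, the lowest of the three numbers, so the least compound is tolerated here. Compound 3 `CCC(CC)NC(=O)c1cccc2[nH]c(-c3ccc(OC)c(OC)c3OC)nc12` gives 32.3 uM. Among the measured compounds shown here, the one step between close relatives, a 14-fold higher number from compound 2 to compound 3 (1.16 log units; beyond the scatter), comes from a methoxy in place of hydrogen on an aromatic carbon and leaves compound 3 close to compound 1.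

The next compound, compound 4 `COc1ccc(-c2nc3c(C(=O)Nc4nc5ccccc5[nH]4)cccc3[nH]2)cc1OC`, differs from compound 2 in one place: 1H-benzimidazol-2-yl in place of pentan-3-yl on an amide-type nitrogen. For the measured compounds named here, no measured step covers this kind of change. The step from compound 2 to compound 3 touches a different part of the molecule and says nothing about the amide side. Compound 1 also carries an aromatic group on its amide nitrogen, and more of it is tolerated than of compound 2, but it differs in a second place as well, so it gives no clean comparison. The direction of the step is therefore open, with a moderate rise toward the other two numbers the more likely outcome. Compound 4 is expected to give about 10 uM, within a range from 2 uM to 50 uM. This estimate means an expected step of a 4.5-fold higher number from compound 2 to compound 4 (0.65 log units; beyond the scatter).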

Compound 4, half-maximal toxic concentration: 51.8 uM
Estimate against measurement, compound 4: 5.2-fold (0.71 log units) below; the measured number lies above the stated range.
By their numbers in this assay, from the lowest: compound 2; then compounds 3, 1 and 4 (each within the scatter of the next).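

In this assay, among the compounds shown here, the amide side of compound 2 turns out to matter a great deal: a 23-fold higher number from compound 2 to compound 4 (1.37 log units; beyond the scatter), the first measured change at this position, comes from putting 1H-benzimidazol-2-yl in place of pentan-3-yl on the amide-type nitrogen. The methoxy step had already raised the number through a change elsewhere in the molecule, so two separate single changes have now lifted compound 2 by a large margin, and neither goes against this among the steps shown. The entering group differs from the leaving one in several ways at once, with more heavy atoms, two aromatic rings, ring nitrogens and a hydrogen-bond donor, and nothing measured here says which of these differences matters, or why.

Open, going by these compounds, is whether a simpler ring on the same nitrogen, such as cyclohexyl or 2-pyridyl, would produce a similar rise, which would begin to separate the effect of having a ring from that of the ring nitrogens. Also open, on these data alone, is whether the benzimidazole amide and the added methoxy, brought together in a single molecule, would raise the number further or give no gain beyond either change alone.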